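One fluorophenyl swap, one value still unknown

The compounds below may be only part of what the source reports. "The series", "measured", "known", "first", "only" and "open" are said of these compounds alone.

Measured in a functional assay on cells (Neutrophil, Homo sapiens) for inhibition, with a stated time of 10 min; a lower number here means a stronger inhibitor, a higher number a weaker inhibitor:
- Compound 1 `O=C(Nc1ccc(F)cc1)N1c2ccnn2CC1c1ccccc1`: > 1000 nM
- Compound 2 `NC(=O)c1cnn2c1N(C(=O)Nc1ccccc1F)C(c1ccccc1)C2`: 6.2 nM
- Compound 3 `NC(=O)c1cnn2c1N(C(=O)Nc1cccc(F)c1)C(c1ccccc1)C2`: 1.2 nM

The entry for compound 1 is a limit, not a number. Of the two true numbers, compound 3 holds the lower, and compound 2 is its nearest neighbour. Compound 4 `NC(=O)c1cnn2c1N(C(=O)Nc1ccc(F)cc1)C(c1ccccc1)C2` carries one change from compound 3: 4-fluorophenyl in place of 3-fluorophenyl on an amide-type nitrogen. That is 4-fluorophenyl in place of 3-fluorophenyl on an amide-type nitrogen. Within the data shown here, the one measured step that bears on this is a similar swap, 3-fluorophenyl for 2-fluorophenyl: a 5.2-fold lower number from compound 2 to compound 3 (0.71 log units; beyond the scatter). It is modest but beyond the scatter, so a small shift is expected in this assay, probably towards a higher number. The expected change is a 2.5-fold higher number from compound 3 to compound 4 (0.40 log units; beyond the scatter). For compound 4 the estimate is 3 nM, with an expected range of 1 nM to 9 nM.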

Compound 4, half-maximal inhibitory concentration: 484 nM
Estimate against measurement, compound 4: 160-fold (2.21 log units) below, and the stated range ends below it.
By their numbers in this assay, from the lowest: compound 3; then compound 2; then compound 4. At a limit, above all of these: compound 1.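

With the same atoms joined differently, moving the fluorine to give 4-fluorophenyl produces a 400-fold higher number from compound 3 to compound 4 (2.61 log units; beyond the scatter) and a 78-fold higher number from compound 2 to compound 4 (1.89 log units; beyond the scatter), far larger than the earlier swap between the other two fluorophenyl groups. The carbamoyl group alone therefore does not secure a low number. Carbamoyl in place of hydrogen gives an at least 2.0-fold lower number from compound 1 to compound 4 (0.31 log units; beyond the scatter), a step whose starting entry is a limit: the limit of > 1000 nM in this assay, at which 1 of the 4 values shown sits.

On these data alone, whether chlorine or a methoxy group on this phenyl ring would follow the same order as fluorine stays open. So does how an unsubstituted phenyl would compare.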